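The source may hold more compounds than are shown below. What is called first, only, known or untested is meant among the compounds shown, and "the series" means these compounds.

Working notes on the series. The common part is a diphosphate-bearing sugar with a pyrimidine base attached on a saturated ring carbon. Compound 1 `O=c1[nH]c(=S)ccn1[C@@H]1O[C@H](COP(=O)(O)OP(=O)(O)O)[C@@H](O)[C@H]1O` is the starting point here. Going by the values given here, in an in vitro functional assay on 1321-N1 cells for agonist activity at P2Y purinoceptor 6 (Homo sapiens) (a lower number here means that less compound is needed, a higher number that more compound is needed for the effect), compound 1 gives 80 nM, which is the higher of the two numbers so far. Among the compounds with values here, compound 2 `O=c1cc(I)n([C@@H]2O[C@H](COP(=O)(O)OP(=O)(O)O)[C@@H](O)[C@H]2O)c(=O)[nH]1` carries an iodine on its base, and in this assay compound 2 gives 15 nM, a lower number than compound 1 by a margin beyond the scatter; no single-point step links the two, so only the pair of values is taken as such.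

Compound 3 `O=c1ccn([C@@H]2O[C@H](COP(=O)(O)OP(=O)(O)O)[C@@H](O)[C@H]2O)c(=S)[nH]1` has not been measured. It differs from compound 1 by a group of 8 heavy atoms (4 carbon, 2 nitrogen, 1 oxygen, 1 sulfur; one six-membered aromatic ring with 2 hetero atoms) in place of a group of 8 heavy atoms (4 carbon, 2 nitrogen, 1 oxygen, 1 sulfur; one six-membered aromatic ring with 2 hetero atoms), on a saturated ring carbon; the same atoms are present, joined differently, so the sulfur and the oxygen of the base exchange positions. Within the data shown here, no measured pair covers this change, so the direction has to be guessed. The expectation is that compound 3 moves to a lower number, roughly in line with where compound 2 sits, by a step of a 4.0-fold lower number from compound 1 to compound 3 (0.60 log units; beyond the scatter). Compound 3 is estimated at 20 nM, within 4 nM to 100 nM.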

Compound 3, half-maximal effective concentration: 60 nM
Estimate against measurement, compound 3: 3.0-fold (0.48 log units) below; the range from low to high includes it.
By their numbers in this assay, from the lowest: compound 2; then compounds 3 and 1 (each within the scatter of the next).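

Going by these compounds alone, the exchange of sulfur and oxygen on the base, at the saturated ring carbon next to the ring oxygen, gives a 1.3-fold lower number from compound 1 to compound 3 (0.12 log units; within the scatter) in this assay, the first single-change comparison and one that lies within the scatter. With the same atoms and the same counts of hydrogen-bond donors and acceptors in both groups, this read-out does not separate the two arrangements of the base, so the placement of the sulfur shows no measurable effect in this pair, and the iodine of compound 2 remains unconnected to either compound by any single-place step. Nothing available bears on why the two arrangements read alike.

Open, going by these compounds, is whether the base tolerates other replacements for the sulfur, such as a methoxy group or an amine, and whether a bromine or a chlorine in place of the iodine would hold the value seen for compound 2, which is 15 nM in this assay. Also open, on these data alone, is how an iodine and a sulfur would behave together on one base, and whether a triphosphate chain in place of the diphosphate would alter the picture.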